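The source may report more compounds than this note shows. Statements on the series, on what has been measured and on what is new or still open speak of the compounds shown alone.

Compound 1 `Cc1cc(NC(=O)Cn2nnc(-c3cc(Cl)cc(Cl)c3)n2)n(C2CCCCC2)n1`: 980 nM
Compound 2 `Cc1cc(NC(=O)Cn2nnc(-c3cccc(F)c3)n2)n(C2CCCCC2)n1`: 81 nM
Compound 3 `Cc1cccc(-c2nnn(CC(=O)Nc3cc(C)nn3C3CCCCC3)n2)c1`: 129 nM

All three compounds share one core and differ only in the aryl ring attached to it. In an assay on HEK293 cells for activation of Kir3.1/Kir3.2 (Homo sapiens), read by thallium flux (on this read-out lower numbers stand for an effect already at smaller amounts and higher numbers for an effect only at larger amounts of compound), compound 3 gives 129 nM, the second highest of the three numbers; it sits close to compound 2, since the gap a 1.6-fold higher number from compound 2 to compound 3 (0.20 log units; within the scatter) lies within the scatter, and well apart from compound 1, as a 7.6-fold lower number from compound 1 to compound 3 (0.88 log units; beyond the scatter) is beyond it. Compound 4 `Cc1cc(NC(=O)Cn2nnc(-c3ccc(C(F)(F)F)cc3)n2)n(C2CCCCC2)n1` is not yet measured; it carries 4-(trifluoromethyl)phenyl in place of 3-methylphenyl on an aromatic carbon. Among the measured compounds shown here, no measured step swaps an aryl group for this one, so nothing bears on it directly. What the measured steps do show is that changing the groups on that ring can move the number strongly: a 12-fold lower number from compound 1 to compound 2 (1.08 log units; beyond the scatter) and a 7.6-fold lower number from compound 1 to compound 3 (0.88 log units; beyond the scatter). A step of comparable size in either direction is therefore possible, and its direction remains uncertain. Compound 4 is expected to give about 300 nM, between 80 nM and 1200 nM, which would mean a 2.3-fold higher number from compound 3 to compound 4 (0.37 log units; beyond the scatter).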

Compound 4, half-maximal effective concentration: 241 nM
Estimate against measurement, compound 4: 1.2-fold (0.10 log units) above; measured number inside the range.
By their numbers in this assay, from the lowest: compounds 2, 3 and 4 (each within the scatter of the next, the first and the last beyond it); then compound 1.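

Replacing 3-methylphenyl, with 7 heavy atoms, by 4-(trifluoromethyl)phenyl, with 10 heavy atoms, gives a 1.9-fold higher number from compound 3 to compound 4 (0.27 log units; within the scatter) in this assay, so this position accepts the new group without a change that can be told from the scatter. Against 3-fluorophenyl the same group does show a real difference, a 3.0-fold higher number from compound 2 to compound 4 (0.47 log units; beyond the scatter), while against 3,5-dichlorophenyl the step runs the other way, a 4.1-fold lower number from compound 1 to compound 4 (0.61 log units; beyond the scatter), which leaves compound 1 apart from the other three compounds. No measurement shown here explains these differences.

The compounds shown leave open how the number responds to an aryl ring carrying an amine or a carboxylic acid. They also leave open how 3-(trifluoromethyl)phenyl would compare, so the effect of the trifluoromethyl group cannot yet be separated from where it sits on the ring.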